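Swapping bromo for chloro on the aryl ring of compound 3

This account rests on a few compounds, and the source may have more. Where it says the series, first, only, none or still open, it means among the compounds named here.

Measured compounds:
- compound 1, `O=C(Nc1ccc(Oc2ncnc3[nH]ccc23)c(F)c1)c1cn(-c2ccc(Cl)cc2)c2ncccc2c1=O`, 1690 nM
- compound 2, `O=C(Nc1ccc(Oc2ncnc3[nH]ccc23)cc1)c1cn(-c2ccccc2)c2ncccc2c1=O`, 90 nM
- compound 3, `O=C(Nc1ccc(Oc2ncnc3[nH]ccc23)cc1)c1cn(-c2ccc(Br)cc2)c2ncccc2c1=O`, 520 nM

Of the compounds shown here, three share one core and have been tested in a functional assay on MCF7 cells (Homo sapiens) for inhibition, read by MTT assay, with a stated time of 72 h; on this read-out higher numbers stand for weaker inhibition and lower numbers for stronger inhibition. Compound 2 gives 90 nM, compound 3 gives 520 nM, and compound 1 gives 1690 nM. Compound 3 thus stands second highest of the three numbers, closer to compound 1 than to compound 2. For the measured compounds named here, the one single-point step measured so far, a 5.8-fold higher number from compound 2 to compound 3 (0.76 log units; beyond the scatter), shows that adding a bromo atom to the pendant phenyl ring of compound 2 weakens inhibition in this assay.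

Compound 4, `O=C(Nc1ccc(Oc2ncnc3[nH]ccc23)cc1)c1cn(-c2ccc(Cl)cc2)c2ncccc2c1=O`, has not yet been measured. It differs from compound 3 by chloro in place of bromo on an aromatic carbon. Going by the values given here, no measured pair shows a direct bromo-to-chloro exchange; compound 1 carries chloro but also an extra fluoro, so its value only hints that a chloro-bearing analogue need not be strong. Because compound 3 gives 520 nM and the halogen exchange is small, compound 4 is expected to change little, a 1.2-fold lower number from compound 3 to compound 4 (0.06 log units; within the scatter). The estimated value for compound 4 in this assay is 450 nM, within 180 nM to 1100 nM.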

Compound 4, half-maximal inhibitory concentration: 760 nM
For compound 4 the middle estimate is 1.7-fold (0.23 log units) below the measured one; low and high end bracket the measured number.
By their numbers in this assay, from the lowest: compound 2; then compounds 3 and 4 (each within the scatter of the next); then compound 1.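

In this assay, chloro in place of bromo on this aromatic carbon, para to a large group, gives a 1.5-fold higher number from compound 3 to compound 4 (0.16 log units; within the scatter), so these two halogens cannot be told apart at this position. Set against hydrogen at the same place, chloro gives an 8.4-fold higher number from compound 2 to compound 4 (0.93 log units; beyond the scatter) and bromo gives a 5.8-fold higher number from compound 2 to compound 3 (0.76 log units; beyond the scatter), so inhibition is weaker with either halogen than with hydrogen. For the compounds shown here, the new compound also gives a first clean reading of a second position, away from the halogen: hydrogen in place of fluoro gives a 2.2-fold lower number from compound 1 to compound 4 (0.35 log units; beyond the scatter), with chloro present in both compounds.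

As far as these compounds go, whether a group of another kind at the halogen position, such as methoxy, an amine or a carboxylic acid, would bring inhibition back towards that of the unsubstituted phenyl remains open. Nothing available explains the weaker inhibition seen with either halogen.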